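From Compound 3 to Compound 4: Dropping the Amino Link

The compounds below may be only part of what the source reports. "The series", "measured", "known", "first", "only" and "open" are said of these compounds alone.

Measured so far:
compound 1 `O=C(Nc1cccc(-n2cc(-c3ccncc3)c(-c3ccc(Cl)c(O)c3)n2)c1)Nc1ccc(Cl)c(Cl)c1`: 10900 nM
compound 2 `COc1cc(-c2nn(-c3cccc(NC(=O)c4ccc(Cl)c(C(F)(F)F)c4)c3)cc2-c2ccncc2)ccc1Cl`: a limit, > 32500 nM
compound 3 `COc1cc(-c2nn(-c3cccc(NC(=O)Nc4cccc(C(F)(F)F)c4)c3)cc2-c2ccncc2)ccc1Cl`: 5430 nM

In a functional assay on SF-268 cells (Homo sapiens) for inhibition, read by sulforhodamine B assay, with a stated time of 48 h (a lower number here means a stronger inhibitor of growth, a higher number a weaker inhibitor of growth), compound 3 gives 5430 nM, the lowest of the two plain numbers. Compound 1 gives 10900 nM, which lies within the scatter of compound 3. Compound 2 reports only a limit, > 32500 nM.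

Compound 4 `COc1cc(-c2nn(-c3cccc(NC(=O)c4ccccc4)c3)cc2-c2ccncc2)ccc1Cl` differs from compound 3 in one place: phenyl in place of (3-(trifluoromethyl)phenyl)amino on a carbonyl carbon. Among the measured compounds shown here, one measured step bears on this: an at least 5.9-fold lower number from compound 2 to compound 3 (0.77 log units; beyond the scatter), where a carbon-linked aryl group on the carbonyl carbon gave way to an amino-linked one. Compound 4 reverses that link and also drops the trifluoromethyl, so a higher number is expected, possibly reaching (the limit of > 32500 nM in this assay, at which 1 of the 3 values shown sits).

Compound 4 is estimated at 25000 nM, ranging from 9000 nM to 70000 nM. This expected change is a 4.6-fold higher number from compound 3 to compound 4 (0.66 log units; beyond the scatter).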

Compound 4, concentration for total growth inhibition: > 100000 nM
Compound 4: no number, only a limit; the forecaster's own chance of this, stated with the estimate: 45%; middle value at least 4.0-fold (0.60 log units) from the limit.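

Putting phenyl in place of (3-(trifluoromethyl)phenyl)amino on this carbonyl carbon gives an at least 18-fold higher number from compound 3 to compound 4 (1.26 log units; beyond the scatter) in this assay. Compound 4 gives only a limit: the limit of > 100000 nM in this assay, at which 1 of the 4 values shown sits.

Compound 2 and compound 4, both with a carbon-linked aryl group on the carbonyl carbon, give only limits, and the step between them cannot be read, while compound 1 and compound 3, with an amino-linked aryl group, give plain numbers.

This step removes the amino link and the trifluoromethyl together, and the compounds shown do not separate the two. They also leave open how an unsubstituted phenylamino group or a methylamino group would behave on this carbonyl carbon.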